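The source may report more compounds than this note shows. Statements on the series, on what has been measured and on what is new or still open speak of the compounds shown alone.

Measured compounds:
Compound 1 `CCC(CC)n1c(-c2ccc(OCc3c(-c4c(Cl)cccc4Cl)noc3C(C)C)cc2)nc2ccc(C(=O)O)cc21` gives 26.5 nM in an assay on isolated protein for agonist activity at Bile acid receptor (Homo sapiens), read by TR-FRET; a higher number here means that more compound is needed for the effect, a lower number that less compound is needed.
Compound 2 `CC(C)c1onc(-c2c(Cl)cccc2Cl)c1COc1ccc(-c2nc3ccc(C(=O)O)cc3n2CC2CC2)cc1` gives 29.1 nM in this assay.
Compound 3 `CC(C)c1onc(-c2c(Cl)cccc2Cl)c1COc1ccc(-c2nc3ccc(C(=O)O)cc3n2C2CCCC2)cc1` gives "not determined" (no result reported) in this assay.

Compound 3 therefore stands nowhere on the numbers shown: its result in this assay was not determined, and only its structure is known. The unmeasured compound 4 `CCCn1c(-c2ccc(OCc3c(-c4c(Cl)cccc4Cl)noc3C(C)C)cc2)nc2ccc(C(=O)O)cc21` differs from it in one place: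

propyl in place of cyclopentyl on an aromatic nitrogen

Among the compounds with values here, no measured pair changes cyclopentyl to propyl, so the only guidance comes from the one pair that varies the group on the same aromatic nitrogen. There, a 1.1-fold higher number from compound 1 to compound 2 (0.04 log units; within the scatter), which is within the scatter: a branched chain and a small ring-bearing chain on that nitrogen gave the same outcome in this assay. Both measured compounds sit close together, and nothing in this set points to that position as one where size of the group moves the number. On that basis no step beyond the scatter is expected from compound 3 to compound 4, and compound 4 is expected to land near the values of compounds 1 and 2. The estimate for compound 4 in this assay is 30 nM, with a range of 12 nM to 75 nM.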

Compound 4, half-maximal effective concentration: 96.4 nM
Compound 4: the middle estimate sits 3.2-fold (0.51 log units) below what was measured; the measured number lies above the stated range.
By their numbers in this assay, from the lowest: compounds 1 and 2 (each within the scatter of the next); then compound 4.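

With propyl on the aromatic nitrogen, the number in this assay moves beyond the scatter in both readable comparisons, with a 3.3-fold higher number from compound 2 to compound 4 (0.52 log units; beyond the scatter) and a 3.6-fold higher number from compound 1 to compound 4 (0.56 log units; beyond the scatter). This shows what compound 1 and compound 2 could not show on their own: the position does respond to the group it carries, and the agreement between pentan-3-yl and cyclopropylmethyl does not extend to every group placed there. The steps are modest, and nothing measured here gives a reason for them.

From the compounds shown here alone, compound 3 has no result, so the change from cyclopentyl to propyl cannot itself be read, and it remains open whether cyclopentyl would fall with pentan-3-yl and cyclopropylmethyl or with propyl. Also open, going by these compounds, is whether the number would keep rising along a series of straight chains, and how a longer chain such as butyl, or a chain ending in an amine, would behave on this nitrogen.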